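Chloro to trifluoromethyl on the aryl ring of compound 1

The source may report more compounds than this note shows. Statements on the series, on what has been measured and on what is new or still open speak of the compounds shown alone.

Compound 1 `O=C1C=CC2(C=C1)OCC(=O)N2c1nc(-c2ccc3ccccc3c2)nn1-c1ccc(Cl)cc1` is tested in a functional assay on HeLa cells (Homo sapiens) for antiproliferative activity, with a stated time of 5 days (on this read-out higher numbers stand for weaker inhibition and lower numbers for stronger inhibition), and gives 720 nM, the higher of the two numbers recorded so far. Compound 2 `CC1OC2(C=CC(=O)C=C2)N(c2nc(-c3cccc4ccccc34)nn2-c2ccccc2)C1=O` differs from compound 1 in several places at once; in this assay compound 2 gives 110 nM. Among the measured compounds shown here, no single-change step between these two is available. Compound 3 `O=C1C=CC2(C=C1)OCC(=O)N2c1nc(-c2ccc3ccccc3c2)nn1-c1ccc(C(F)(F)F)cc1` differs from compound 1 in one place only: trifluoromethyl in place of chloro on an aromatic carbon. For the measured compounds named here, no measured pair shows this change, so the step in this assay is expected to be small and may fall within the scatter, in either direction. Compound 3 is estimated at 550 nM, with a range of 180 nM to 1700 nM. The expected step is a 1.3-fold lower number from compound 1 to compound 3 (0.12 log units; within the scatter).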

Compound 3, half-maximal inhibitory concentration: 390 nM
Beside the measured number, compound 3's estimate is 1.4-fold (0.15 log units) above it, and the stated range covers the measured number.
By their numbers in this assay, from the lowest: compound 2; then compounds 3 and 1 (each within the scatter of the next).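

In this assay the series now has its first single-change step, a 1.8-fold lower number from compound 1 to compound 3 (0.27 log units; within the scatter), and it concerns the aromatic carbon para to a large group. Trifluoromethyl in place of chloro at this position therefore leaves the number within the scatter, so this one change does not separate 4-chlorophenyl from 4-(trifluoromethyl)phenyl. Nothing measured here speaks to the reason for this result.

From the compounds shown here alone, whether this position responds to a change of group at all remains open. An amine, a carboxylic acid or a longer alkyl chain on the same aromatic carbon would test that.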